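The source may report more compounds than this note shows. Statements on the series, on what has been measured and on what is new or still open speak of the compounds shown alone.

Measured compounds:
- Compound 1, `CCCCCCCCC(=O)N1c2ccccc2CCC1C(=O)Nc1ccccc1C(F)(F)F`, in a functional assay on NUGC-3 cells (Homo sapiens) for cytotoxicity, read by sulforhodamine B assay, with a stated time of 72 h; a lower number here means a stronger inhibitor of growth, a higher number a weaker inhibitor of growth: 6180 nM
- Compound 2, `O=C(Nc1cc(C(F)(F)F)cc(C(F)(F)F)c1)C1CCc2ccccc2N1C(=O)c1ccc(Cl)cc1`: 1660 nM
- Compound 3, `O=C(Nc1cc(C(F)(F)F)cc(C(F)(F)F)c1)C1CCc2ccccc2N1C(=O)c1cccc(Cl)c1`: 560 nM

Among these three, compound 3 stands lowest, giving 560 nM in this assay. Its nearest neighbour in number is compound 2, and the single-change step between them, a 3.0-fold lower number from compound 2 to compound 3 (0.47 log units; beyond the scatter), is modest but beyond the scatter. Among the measured compounds shown here, compound 1, which carries both a long acyl chain and a different anilide part, lies furthest from compound 3; in this assay compound 1 gives 6180 nM, and no single step is defined between those two, so their values only show that the long-chain compound sits well above the aryl-carbonyl compounds.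

Compound 4, `CCCC(=O)N1c2ccccc2CCC1C(=O)Nc1cc(C(F)(F)F)cc(C(F)(F)F)c1`, has not yet been measured. Its difference from compound 3 is propyl in place of 3-chlorophenyl on a carbonyl carbon. For the measured compounds named here, no measured step covers an exchange of an aromatic carbonyl substituent for a short chain, so the only guidance is indirect: the one measured step, a 3.0-fold lower number from compound 2 to compound 3 (0.47 log units; beyond the scatter), concerns a change within the chlorophenyl group and does not bear directly on its removal, while the two values of compound 1 and compound 3 hint that a plain alkyl chain on that carbonyl goes with a higher number. Compound 4 is therefore expected to show a 5.4-fold higher number from compound 3 to compound 4 (0.73 log units; beyond the scatter), a weakening beyond the scatter, with an estimated value of 3000 nM and a range from 800 nM to 12000 nM.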

Compound 4, concentration for 50% growth inhibition: 14400 nM
The estimate for compound 4 lay 4.8-fold (0.68 log units) below the measured number, outside the stated range (above it).
By their numbers in this assay, from the lowest: compound 3; then compound 2; then compound 1; then compound 4.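

In this assay, among the compounds shown here, compound 4 provides the first measured exchange of an aromatic group for a plain chain on this carbonyl carbon, whose other neighbour is the amide-type nitrogen in a ring. Propyl in place of 3-chlorophenyl gives a 26-fold higher number from compound 3 to compound 4 (1.41 log units; beyond the scatter), a large step, while propyl in place of 4-chlorophenyl gives an 8.7-fold higher number from compound 2 to compound 4 (0.94 log units; beyond the scatter), a modest step, and both lie beyond the scatter. For the compounds shown here, the earlier step showed only that the two chlorophenyl groups differ from each other; these steps show that, with the rest of the molecule unchanged, either chlorophenyl group goes with a lower number than propyl, although the size of the change depends on which chlorophenyl group is replaced.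

An unsubstituted phenyl, a cyclohexyl or a longer chain on this carbonyl carbon, with the rest of compound 4 kept, would be needed to tell apart the roles of the ring, the chlorine and the chain length in these steps. Nothing among the data given accounts for the size of either step.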